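The source may hold more compounds than are shown below. What is called first, only, known or untested is meant among the compounds shown, and "the series" means these compounds.

Compound 1 `CC1(C)CC(=O)C(C(=S)SCCO)=C(Nc2ccc(Cl)cc2)C1` gives 21 ug/mL in a functional assay on PBMC cells (Homo sapiens) for inhibition, read by thymidine incorporation, with a stated time of 72 h; a higher number here means a weaker inhibitor, a lower number a stronger inhibitor.
Compound 2 `CC(=O)OC[C@H]1O[C@@H](SC(=S)C2=C(Nc3ccc(Cl)cc3)CC(C)(C)CC2=O)[C@H](OC(C)=O)[C@@H](OC(C)=O)[C@@H]1OC(C)=O` gives 9.9 ug/mL in this assay.
Compound 3 `CC1(C)CC(=O)C(C(=S)SCCO)=C(Nc2ccc(Br)cc2)C1` gives 8.3 ug/mL in this assay.

Compound 3 differs from compound 1 by bromo in place of chloro on an aromatic carbon, and this change brought a 2.5-fold lower number from compound 1 to compound 3 (0.40 log units; beyond the scatter). Compound 2 and compound 3 lie within the usual scatter of each other, so their order is not settled. The difference between the core of compound 1 and the core of compound 2 is not broken down here.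

Compound 4 `CC(=O)OC[C@H]1O[C@@H](SC(=S)C2=C(Nc3ccc(Br)cc3)CC(C)(C)CC2=O)[C@H](OC(C)=O)[C@@H](OC(C)=O)[C@@H]1OC(C)=O` has not yet been measured. It differs from compound 2 by bromo in place of chloro on an aromatic carbon, and the place of the change is the same as it was from compound 1 to compound 3. Since that earlier step was a 2.5-fold lower number from compound 1 to compound 3 (0.40 log units; beyond the scatter), a step of about the same size is expected here, a 2.2-fold lower number from compound 2 to compound 4 (0.34 log units; beyond the scatter), resting on that single pair alone. Compound 4 is therefore estimated at 4.5 ug/mL in this assay, likely between 2 ug/mL and 10 ug/mL.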

Compound 4, half-maximal inhibitory concentration: 8.8 ug/mL
Compound 4: the middle estimate sits 2.0-fold (0.29 log units) below what was measured; the measured number falls inside the stated range.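

In this assay, putting bromo in place of chloro on the core of compound 2 brought a 1.1-fold lower number from compound 2 to compound 4 (0.05 log units; within the scatter), so on this core the swap leaves no readable change. Set beside the earlier step, the two results cannot be told apart: the same change on two cores in this assay, a 2.5-fold lower number (0.40 log units; beyond the scatter) from compound 1 to compound 3 and a 1.1-fold lower number (0.05 log units; within the scatter) from compound 2 to compound 4, 2.2-fold (0.35 log units) apart, within the scatter of two such steps The shift seen on the core of compound 1 did not clearly repeat on the core of compound 2, yet one pair per core shows neither that the change carries over nor that it depends on the core.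

The compounds shown leave open how fluoro or methoxy on that same aromatic carbon would read in this assay. As far as these compounds go, whether such groups would behave alike on both cores also remains unknown.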